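Replacing Phenyl with Benzyl on a Hydroxamate Scaffold

This account rests on a few compounds, and the source may have more. Where it says the series, first, only, none or still open, it means among the compounds named here.

Of the compounds shown here, three have been measured in an assay on isolated protein for inhibition of protein deacetylase HDAC6 (Homo sapiens), read by fluorescence, with stated times of 10 min and 2 h; a lower number here means a stronger inhibitor, a higher number a weaker inhibitor. Within the data shown here, compound 1 `Cc1ccc(CN2CC(=O)N(Cc3ccc(C(=O)NO)cc3)C2=O)cc1` gives 17.6 nM, and compound 2 `COc1ccc(CN2CC(=O)N(Cc3ccc(C(=O)NO)cc3)C2=O)cc1` gives 28.2 nM; the one change between them, a 1.6-fold higher number from compound 1 to compound 2 (0.20 log units; within the scatter), stays within the scatter. Compound 3 `O=C(NO)c1ccc(CN2C(=O)NC(Cc3ccccc3)(c3ccccc3)C2=O)cc1`, built on a different core, gives 71.9 nM, the highest number of the three and so the weakest inhibitor, as its gaps to compound 1 and to compound 2 both lie beyond the scatter.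

Compound 4 `O=C(NO)c1ccc(CN2C(=O)NC(CCc3ccccc3)(c3ccccc3)C2=O)cc1` differs from compound 3 in one place: benzyl in place of phenyl on a saturated chain carbon bound to a saturated ring carbon. Among the measured compounds shown here, no measured step matches this change. For the measured compounds named here, the only measured step, between compound 1 and compound 2, swaps methyl for methoxy on an aromatic carbon of another core and offers no guide to putting benzyl in place of phenyl on a saturated chain carbon. Without such a guide, the expected step is one that stays within the scatter, and a 1.0-fold lower number from compound 3 to compound 4 (0.01 log units; within the scatter) is what is expected. Compound 4 is therefore estimated at 70 nM, with a likely range from 30 nM to 170 nM.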

Compound 4, half-maximal inhibitory concentration: 24.7 nM
For compound 4 the middle estimate is 2.8-fold (0.45 log units) above the measured one, outside the stated range (below it).
By their numbers in this assay, from the lowest: compounds 1, 4 and 2 (each within the scatter of the next); then compound 3.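

In this assay, among these compounds, benzyl in place of phenyl on a saturated chain carbon bound to a saturated ring carbon gives a 2.9-fold lower number from compound 3 to compound 4 (0.46 log units; beyond the scatter), a modest step but one beyond the scatter, so this position responds to the change, whereas the only earlier step, on another core, stayed within the scatter. Read one bond further out, the change is benzyl to phenethyl; neither group holds a hydrogen-bond donor or acceptor or a net charge, and each holds one six-membered aromatic ring of carbon only, so the visible difference lies in the chain leading to that ring. What lies behind the size of this step has no measured support here.

Going by these compounds, whether a longer chain, such as phenylpropyl, would lower the number further remains open. So does the effect of an amine or a carboxylic acid at the end of this chain.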